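Moving the Chlorine on a Benzylamine Side Chain

The source may report more compounds than this note shows. Statements on the series, on what has been measured and on what is new or still open speak of the compounds shown alone.

Compound 2 `CN(CCCCn1c(=O)oc2ccccc21)Cc1cccc(Cl)c1` carries a 3-chlorobenzyl group on an amine nitrogen, with a four-carbon chain linking that nitrogen to the shared core. In an assay on membranes from liver for displacement of a labelled ligand from Sigma non-opioid intracellular receptor 1 (Rattus norvegicus), read by scintillation counting (on this read-out lower numbers stand for stronger inhibition and higher numbers for weaker inhibition), compound 2 gives 302 nM, the second highest of the three numbers measured. Compound 1 `Cc1ccc(CN(C)CCCCn2c(=O)oc3ccccc32)c(C)c1`, which has a 2,4-dimethylphenyl ring in the same place, gives 239 nM in this assay; the step of a 1.3-fold higher number from compound 1 to compound 2 (0.10 log units; within the scatter) lies within the scatter, so the two cannot be ranked against each other. Within the data shown here, compound 3 `CN(CCCn1c(=O)oc2ccccc21)Cc1cccc(Cl)c1` keeps the 3-chlorobenzyl group of compound 2 but has a three-carbon chain, and in this assay compound 3 gives 3230 nM; no single step links it to compound 2, and its number simply stands higher than the other two.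

Compound 4 `CN(CCCCn1c(=O)oc2ccccc21)Cc1ccc(Cl)cc1` differs from compound 2 in one place: 4-chlorophenyl in place of 3-chlorophenyl on a saturated chain carbon bound to an amine nitrogen. Among the measured compounds shown here, the only measured step touching this position, a 1.3-fold higher number from compound 1 to compound 2 (0.10 log units; within the scatter), exchanged the whole aryl group and still stayed within the scatter. Shifting the chlorine within the same ring is therefore expected to bring no step beyond the scatter, that is a 1.0-fold lower number from compound 2 to compound 4 (0.00 log units; within the scatter). Compound 4 is estimated at 300 nM, with a range from 120 nM to 800 nM.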

Compound 4, inhibition constant: 7.1 nM
For compound 4 the middle estimate is 42-fold (1.63 log units) above the measured one; measured number below the stated range.
By their numbers in this assay, from the lowest: compound 4; then compounds 1 and 2 (each within the scatter of the next); then compound 3.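

Compound 2 and compound 4 hold the same atoms, and only the chlorine has moved, yet this assay gives a 43-fold lower number from compound 2 to compound 4 (1.63 log units; beyond the scatter). This shows that the aryl group on a saturated chain carbon bound to an amine nitrogen is not as forgiving as the earlier exchange of a whole ring suggested: in this series, the place of one chlorine on the ring can change the number far beyond the scatter. The 4-chlorophenyl ring also stands apart from the 2,4-dimethylphenyl ring, with a 34-fold lower number from compound 1 to compound 4 (1.53 log units; beyond the scatter), although no measurement shown here gives a reason for the size of either step.

From the compounds shown here alone, it remains open whether chlorine itself is needed, or whether a 4-bromophenyl or 4-methylphenyl ring would give a similarly low number, and how a 2-chlorophenyl ring would compare. Going by these compounds, it also remains open whether the 4-chlorobenzyl group would keep this low number on the shorter chain of compound 3.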